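The source may report more compounds than this note shows. Statements on the series, on what has been measured and on what is new or still open speak of the compounds shown alone.

Measured so far:
compound 1, `CCCCCCCCCCCC(=O)OCC(COC(=O)CCCCCCCCCCC)O[C@@H]1O[C@H](CS(=O)(=O)O)[C@@H](O)[C@H](O)[C@H]1O`, gives 77% in an assay on isolated protein for inhibition of RAC-alpha serine/threonine-protein kinase (Homo sapiens), read by ELISA, tested at 100 uM; a lower number here means less inhibition, a higher number more inhibition at the concentration tested (going by the name of the read-out).
compound 2, `CCCCCCCCO[C@@H]1O[C@H](CN)[C@@H](O)[C@H](O)[C@H]1O`, gives 6% in this assay.

Among the compounds with values here, compound 2 stands lowest of the two numbers so far; its nearest neighbour is compound 1, which sits higher by a margin beyond the usual scatter. Within the data shown here, only these two readings exist, and no pair of measured compounds differs in a single place, so no measured step can guide the next comparison.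

The new compound 3, `CCCCCCCCO[C@@H]1O[C@H](CS(=O)(=O)O)[C@@H](O)[C@H](O)[C@H]1O`, keeps the octyl chain and the sugar of compound 2 and differs from it in one spot: sulfo in place of amino on a saturated chain carbon bound to a saturated ring carbon. The sulfo group that enters is the same group carried by compound 1, though compound 1 also bears two long acyl chains that compound 3 lacks, so its high reading cannot simply be carried over.

In this assay the step from compound 2 to compound 3 is expected to be a number 24 percentage points higher from compound 2 to compound 3 (beyond the scatter), an increase beyond the scatter, because compound 1 with the sulfo group gives 77%. Compound 3 is therefore estimated at 30%, within a range from 5% to 65%.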

Compound 3, a percentage reported as inhibition, at one concentration (the size of the read-out at that concentration, not a potency): 14%
Estimate against measurement, compound 3: 16 percentage points above; the measured number falls inside the stated range.
By their numbers in this assay, from the lowest: compounds 2 and 3 (each within the scatter of the next); then compound 1.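

Replacing amino with sulfo on a saturated chain carbon bound to a saturated ring carbon amounts to a number 8 percentage points higher from compound 2 to compound 3 (within the scatter) in this assay and so, with the octyl chain kept, this swap gives no change that can be told apart from repeat-measurement noise. The sulfo group on the octyl compound therefore does not by itself reproduce the high reading: where compound 3 has the octyl chain, compound 1 carries two long acyl chains and gives 77% with the same sulfo group. Nothing measured here explains the size of this step.

Still open, as far as these compounds go, is whether the same swap would matter on the scaffold with two acyl chains, where an amine in place of the sulfo group of compound 1 would give the direct comparison. Also open, from the compounds shown here alone, is how a carboxylic acid at this position, or a longer chain in place of the octyl chain of compound 3, would read in this assay and how much of the reading of compound 1 belongs to its acyl chains.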